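The compounds below may be only part of what the source reports. "The series", "measured", "known", "first", "only" and "open" are said of these compounds alone.

In an assay on microsomes for inhibition of acyl-CoA:cholesterol acyltransferase (Oryctolagus cuniculus) (a lower number here means a stronger inhibitor, a higher number a weaker inhibitor), compound 3 `CC(C)c1cccc(C(C)C)c1NC(=O)NCC1(c2ccccc2C(F)(F)F)CCCC1` gives 18 nM, the lowest of the three numbers shown, though compound 1 `Cc1ccc(C2(CNC(=O)Nc3c(C(C)C)cccc3C(C)C)CCCC2)cc1` with 25 nM and compound 2 `CC(C)c1cccc(C(C)C)c1NC(=O)NCC1(c2cccc(OCc3ccccc3)c2)CCCC1` with 30 nM both stay within the usual scatter of it. Compound 4 `CC(C)c1cccc(C(C)C)c1NC(=O)NCC1(c2ccc(CO)cc2)CCCC1` differs from compound 3 in one place: 4-(hydroxymethyl)phenyl in place of 2-(trifluoromethyl)phenyl on a saturated ring carbon. Going by the values given here, the only measured step at the same saturated ring carbon is a 1.4-fold lower number from compound 1 to compound 3 (0.14 log units; within the scatter), and the value of compound 2 shows that a third group at that carbon also stays close to the other two. Compound 4 is therefore expected to show no step beyond the scatter, with a 1.7-fold higher number from compound 3 to compound 4 (0.22 log units; within the scatter) as the estimated change. The estimated value for compound 4 is 30 nM, with a range from 12 nM to 80 nM.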

Compound 4, half-maximal inhibitory concentration: 26 nM
Estimate against measurement, compound 4: 1.2-fold (0.06 log units) above; measured number inside the range.
By their numbers in this assay, from the lowest: compounds 3, 1, 4 and 2 (each within the scatter of the next).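

Replacing 2-(trifluoromethyl)phenyl, with no hydrogen-bond donor or acceptor, by 4-(hydroxymethyl)phenyl, with one of each, gives a 1.4-fold higher number from compound 3 to compound 4 (0.16 log units; within the scatter) in this assay, so this group on the saturated ring carbon keeps the number within the scatter. Hydroxy in place of hydrogen on the saturated chain carbon bound to an aromatic carbon likewise gives a 1.0-fold higher number from compound 1 to compound 4 (0.02 log units; within the scatter) and thus leaves the number essentially unmoved. Nothing measured here explains this result. Open, as far as these compounds go, is whether an amine or a carboxylic acid on that chain carbon would stay as close, and whether a longer chain carrying the hydroxy would.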